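The source may report more compounds than this note shows. Statements on the series, on what has been measured and on what is new or still open speak of the compounds shown alone.

Of the compounds shown here, three have been measured in an ADME assay on Caco-2 cells (Homo sapiens) for permeability, in the apical to basolateral direction; a higher number here means that the compound crosses the layer faster, a lower number that the compound crosses the layer more slowly. Compound 1 `Cc1c(NC(=O)c2ccc(C(C)(C)C)cc2)cccc1-c1ccnc2[nH]c(-c3cnn(C)c3)nc12` gives 0.6 10^-6 cm/s. Compound 2 `Cn1cc(-c2nc3c(-c4ccc(CNC(=O)c5nc(C(C)(C)C)no5)c(F)c4)ccnc3[nH]2)cn1` gives 11 10^-6 cm/s, and compound 3 `Cn1cc(-c2nc3c(-c4ccc(CNC(=O)c5noc(C(C)(C)C)n5)c(F)c4)ccnc3[nH]2)cn1` gives 2.5 10^-6 cm/s, the second highest of the three, sitting between the other two at a gap beyond the scatter in each direction. For the measured compounds named here, the one step that changes a ring on the carbonyl carbon, a 4.4-fold lower number from compound 2 to compound 3 (0.64 log units; beyond the scatter), shows that exchanging one five-membered aromatic ring for another at this place can move the number by a modest amount. Compound 4 `Cn1cc(-c2nc3c(-c4ccc(CNC(=O)c5cc6c(s5)CCCC6)c(F)c4)ccnc3[nH]2)cn1` differs from compound 3 in that (a group of 9 heavy atoms (8 carbon, 1 sulfur; one five-membered aromatic ring with 1 hetero atom, one six-membered non-aromatic ring of carbon only) in place of a group of 9 heavy atoms (6 carbon, 2 nitrogen, 1 oxygen; one five-membered aromatic ring with 3 hetero atoms), on a carbonyl carbon). Going by the values given here, no measured step covers this exchange, so the estimate for compound 4 rests loosely on the size seen in a 4.4-fold lower number from compound 2 to compound 3 (0.64 log units; beyond the scatter) and is 6 10^-6 cm/s, within 2 10^-6 cm/s to 18 10^-6 cm/s, which would mean a step of a 2.4-fold higher number from compound 3 to compound 4 (0.38 log units; beyond the scatter).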

Compound 4, apparent permeability: 0.6 10^-6 cm/s
Compound 4: the middle estimate sits 10-fold (1.00 log units) above what was measured, outside the stated range (below it).
By their numbers in this assay, from the lowest: compounds 1 and 4 (each within the scatter of the next); then compound 3; then compound 2.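

For the compounds shown here, with the group on the carbonyl carbon as the only change, the fused ring group that enters gives a 4.2-fold lower number from compound 3 to compound 4 (0.62 log units; beyond the scatter) and an 18-fold lower number from compound 2 to compound 4 (1.26 log units; beyond the scatter) in this assay. This position can therefore move the number further than the exchange between the two rings with 3 hetero atoms alone had shown, and both compounds carrying those rings stand beyond the scatter above compound 4. Nothing supplied here accounts for this drop.

As far as these compounds go, it remains open whether the sulfur-containing ring or the fused carbon ring goes with the lower number. From the compounds shown here alone, how an amine or a carboxylic acid on the group at this carbonyl carbon would read also remains open.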